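Swapping a pentylamino chain for ethoxy on the shared core

The source may report more compounds than this note shows. Statements on the series, on what has been measured and on what is new or still open speak of the compounds shown alone.

The series shares one core, carried by compound 1 `Cc1nc(N)c2nc(O)n(Cc3ccccc3)c2n1`, compound 2 `CCCSc1nc(N)c2nc(O)n(Cc3ccccc3)c2n1` and compound 3 `CCCCCNc1nc(N)c2nc(O)n(Cc3ccccc3)c2n1`. In a functional assay on the whole organism for activation, with Mus musculus as the target (a lower number here means that less compound is needed, a higher number that more compound is needed for the effect), compound 1 gives 3 mg/kg, compound 2 gives 0.1 mg/kg and compound 3 gives 0.3 mg/kg. Among these three numbers compound 3 stands second highest: the gap a 3.0-fold higher number from compound 2 to compound 3 (0.48 log units; beyond the scatter) puts it close to compound 2, while a 10-fold lower number from compound 1 to compound 3 (1.00 log units; beyond the scatter) separates it more widely from compound 1.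

Compound 4 `CCOc1nc(N)c2nc(O)n(Cc3ccccc3)c2n1` has not yet been measured in this assay. It differs from compound 3 in one place, (ethoxy in place of pentylamino on an aromatic carbon).

Among the measured compounds shown here, three steps bear on the expectation. Replacing methyl by propylsulfanyl gave a 30-fold lower number from compound 1 to compound 2 (1.48 log units; beyond the scatter), replacing methyl by pentylamino gave a 10-fold lower number from compound 1 to compound 3 (1.00 log units; beyond the scatter), and moving from propylsulfanyl to pentylamino gave a 3.0-fold higher number from compound 2 to compound 3 (0.48 log units; beyond the scatter). Both longer substituents therefore lowered the number well beyond the scatter relative to methyl. Ethoxy is shorter than either of them, and the data hold no direct measurement of an alkoxy group on this carbon. The account therefore expects compound 4 to fall between compound 1 and compound 3, as a step of a 3.3-fold higher number from compound 3 to compound 4 (0.52 log units; beyond the scatter) towards a higher number.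

The estimate for compound 4 in this assay is 1 mg/kg, with a range from 0.3 mg/kg to 3 mg/kg.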

Compound 4, minimum effective dose: 0.3 mg/kg
The estimate for compound 4 lay 3.3-fold (0.52 log units) above the measured number; low and high end bracket the measured number.
By their numbers in this assay, from the lowest: compound 2; then compounds 3 and 4 (each within the scatter of the next); then compound 1.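

In this assay, ethoxy in place of pentylamino gives no change at the digits printed from compound 3 to compound 4 (within the scatter), so on this aromatic carbon between two ring nitrogen atoms, a group of 3 heavy atoms with 0 hydrogen-bond donors matches one of 6 heavy atoms with 1 hydrogen-bond donor. Ethoxy also retains the gain over methyl, with a 10-fold lower number from compound 1 to compound 4 (1.00 log units; beyond the scatter), which shows that the number does not simply follow chain size from ethoxy to pentylamino. It does not reach propylsulfanyl, however, with a 3.0-fold higher number from compound 2 to compound 4 (0.48 log units; beyond the scatter), leaving compound 2 with the lowest number of the four, and nothing available explains these steps.

The compounds shown change the atom linking the chain to the ring together with the chain itself, so the separate contributions of sulfur, oxygen and nitrogen remain open; propoxy and propylamino, set against the propylsulfanyl of compound 2, would separate the linking atom from the chain. Also open, as far as these compounds go, is how far the chain can be shortened or lengthened on this carbon, from methoxy at one end to pentyloxy at the other, before the number moves back towards that of compound 1 or changes in some other way.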